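The compounds below may be only part of what the source reports. "The series", "measured", "known", "first", "only" and "open" are said of these compounds alone.

Measured so far in a functional assay on MCF7 cells (Homo sapiens) for inhibition, read by MTT assay, with a stated time of 48 h; on this read-out higher numbers stand for weaker inhibition and lower numbers for stronger inhibition:

Compound 1, `c1ccc(CSc2nnc(-c3ccncc3)n2-c2ccccc2)cc1`: 22400 nM
Compound 2, `O=C(CSc1nnc(-c2ccncc2)n1-c1ccccc1)N/N=C/c1ccc([N+](=O)[O-])cc1`: 15300 nM
Compound 3, `O=C(CSc1nnc(-c2ccncc2)n1-c1ccccc1)N/N=C/c1ccc(O)cc1`: > 50000 nM

Compound 3 stands at the assay limit; its value of > 50000 nM is a limit and not a number, the one shown in the limit of > 50000 nM in this assay, at which 1 of the 3 values shown sits. It is the weakest point on the numbers shown, since the only step that reaches it, an at least 3.2-fold higher number from compound 2 to compound 3 (0.51 log units; beyond the scatter), lies beyond the scatter. Compound 1 carries no hydrazone at all and sits between compound 2 and the limit.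

Compound 4, `O=C(CSc1nnc(-c2ccncc2)n1-c1ccccc1)N/N=C/c1ccccc1F`, differs from compound 3 by 2-fluorophenyl in place of 4-hydroxyphenyl on a carbon with a double bond to nitrogen. Going by the values given here, the only measured step that bears on this position is an at least 3.2-fold higher number from compound 2 to compound 3 (0.51 log units; beyond the scatter), which shows that a change of the aryl substituent on the hydrazone moves the number beyond the scatter. The replacement in compound 4 removes the hydroxy group again, so the number is expected to fall back toward the region of compound 2 and compound 1, though only as a direction, since compound 3 is known as a limit. The expected step is an at least 2.0-fold lower number from compound 3 to compound 4 (0.30 log units; that floor lies within the scatter). Compound 4 is therefore estimated at 25000 nM in this assay, within a range of 10000 nM to 60000 nM.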

Compound 4, half-maximal inhibitory concentration: 22400 nM
Compound 4: the middle estimate sits 1.1-fold (0.05 log units) above what was measured; low and high end bracket the measured number.
By their numbers in this assay, from the lowest: compounds 2, 1 and 4 (each within the scatter of the next). At a limit, above all of these: compound 3.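

In this assay, 2-fluorophenyl in place of 4-hydroxyphenyl on a carbon with a double bond to nitrogen gives an at least 2.2-fold lower number from compound 3 to compound 4 (0.34 log units; beyond the scatter), so a second change at this position moves the number, and the size of that step is only a floor. With 2-fluorophenyl in place of 4-nitrophenyl the result is a 1.5-fold higher number from compound 2 to compound 4 (0.17 log units; within the scatter), so these two aryl groups are not told apart here, and among the three hydrazones only compound 3 stands apart. The value of compound 3 remains a limit and not a number: the limit of > 50000 nM in this assay, at which 1 of the 4 values shown sits.

Still open is whether the step from compound 3 to compound 4 follows the loss of hydroxy or the entry of fluorine, as no pair shown changes only one of these. Also open, on these data alone, is how an amine or a carboxylic acid on this aryl ring would read in this assay.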